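The source may report more compounds than this note shows. Statements on the series, on what has been measured and on what is new or still open speak of the compounds shown alone.

Working notes on the series. In an assay on Prostate gland for inhibition of steroid 5-alpha-reductase (Rattus norvegicus) (a higher number here means a weaker inhibitor, a lower number a stronger inhibitor), compound 1 `C/C(=C\C(=O)Nc1ccccc1OCCCC(=O)O)c1ccc2c(ccn2CC(C)C)c1` gives 160 nM, and compound 2 `CCCC(CC)n1ccc2cc(/C(C)=C/C(=O)Nc3ccccc3OCCCC(=O)O)ccc21` gives 9.3 nM. Going by the values given here, compound 2 holds the lowest of the two numbers so far; the only step on record, a 17-fold lower number from compound 1 to compound 2 (1.24 log units; beyond the scatter), is the one that separates it from compound 1. Compound 3 `CCCC(C(C)C)n1ccc2cc(/C(C)=C/C(=O)Nc3ccccc3OCCCC(=O)O)ccc21` differs from compound 2 in one place: methyl in place of hydrogen on a saturated chain carbon bound to two saturated chain carbons, so that the chain on the aromatic nitrogen reads 1-isopropylbutyl instead of 1-ethylbutyl. Among the compounds with values here, the single measured step bears on this change only in that it also altered the chain on the aromatic nitrogen, and it was large; the present change is smaller in kind, a single added methyl on a saturated chain carbon bound to two saturated chain carbons, and no second example of such an addition has been measured. A modest step in this assay, estimated as a 1.3-fold lower number from compound 2 to compound 3 (0.12 log units; within the scatter), is expected for compound 3, likely within or just beyond the scatter. The estimate for compound 3 in this assay is 7 nM, with a range from 2.5 nM to 25 nM.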

Compound 3, half-maximal inhibitory concentration: 7.2 nM
For compound 3 the middle estimate is 1.0-fold (0.01 log units) below the measured one; low and high end bracket the measured number.
By their numbers in this assay, from the lowest: compounds 3 and 2 (each within the scatter of the next); then compound 1.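

In this assay, ethyl to isopropyl on the saturated chain carbon bound to two saturated chain carbons amounts to a 1.3-fold lower number from compound 2 to compound 3 (0.11 log units; within the scatter), so this added methyl leaves 1-isopropylbutyl and 1-ethylbutyl indistinguishable. The result gives a second chain on the aromatic nitrogen that stands well apart from isobutyl, with a 22-fold lower number from compound 1 to compound 3 (1.35 log units; beyond the scatter), and the large gain seen earlier is therefore not confined to 1-ethylbutyl. No measurement available here accounts for either step.

The compounds shown leave open how far this chain can grow before the number moves beyond the scatter, for example with tert-butyl or cyclohexyl in place of isopropyl. They also leave open whether a hydroxyl or an amine on the same chain would be accepted in this assay.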